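The compounds below may be only part of what the source reports. "The series", "measured", "known", "first", "only" and "open" are said of these compounds alone.

Measured compounds:
Compound 1 `C=C[C@@](C)(/C=C/c1ccc(O)cc1)CC/C=C/C(=O)OCC`, in a functional assay on SEM cells (Homo sapiens) for cytotoxicity, with a stated time of 72 h (a lower number here means that less compound is needed, a higher number that more compound is needed for the effect), a limit of > 36600 nM.
Compound 2 `C=C[C@@](C)(/C=C/c1ccc(O)cc1)CC/C=C/C(=O)OCc1ccccc1`, in this assay a limit of > 36600 nM.
Compound 3 `C=C[C@@](C)(/C=C/c1ccc(O)cc1)CC/C=C(C)/C=C/C(=O)OCC`, in this assay a limit of > 36600 nM.

Each of these values is a limit of the assay and not a number: the limit of > 36600 nM in this assay, at which 3 of the 3 values shown sit. The change from compound 1 to compound 2 is phenyl in place of methyl on a saturated chain carbon bound to an oxygen next to a carbonyl group, and its step that the two limits leave unreadable from compound 1 to compound 2 cannot be read from two limits. Compound 4 `C=C[C@@](C)(/C=C/c1ccc(O)cc1)CC/C=C(C)/C=C/C(=O)OCc1ccccc1` remains to be measured; it differs from compound 3 by phenyl in place of methyl on a saturated chain carbon bound to an oxygen next to a carbonyl group, the same change at the same place. The difference between the cores of compound 1 and compound 3 is not broken down here. For compound 4 the step expected is a step that the limit leaves unreadable from compound 3 to compound 4, resting on the unreadable step that the two limits leave unreadable from compound 1 to compound 2 and on (the limit of > 36600 nM in this assay, at which 3 of the 3 values shown sit). Compound 4 is therefore expected to give about 50000 nM in this assay, most likely again only as a limit, within 30000 nM to 150000 nM.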

Compound 4, half-maximal effective concentration: > 36600 nM
Compound 4: no number, only a limit; the forecaster's own chance of this, stated with the estimate: 85%; the middle value does not contradict the limit.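

Among these compounds, compound 4 gives > 36600 nM in this assay, which is a limit and not a number, and no step between compound 3 and compound 4 can be read. The compounds shown leave open whether phenyl in place of methyl changes the value at all.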